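The compounds below may be only part of what the source reports. "The series", "measured", "known", "first", "only" and "open" are said of these compounds alone.

Measured compounds in a functional assay on MDA-MB-231 cells (Homo sapiens) for inhibition, read by CCK-8 assay, with a stated time of 48 h; a higher number here means a weaker inhibitor of growth, a lower number a stronger inhibitor of growth:

- compound 1, `Cc1ccccc1Nc1nc(Nc2ccccc2)ncc1Cl`: in this assay compound 1 gives > 100000 nM, which is a limit of the assay and not a number.
- compound 2, `Cc1ccccc1Nc1nc(NCc2ccccc2)ncc1Cl`: in this assay compound 2 gives > 100000 nM, again a limit rather than a number.
- compound 3, `CN1CCN(c2ccc(Nc3ncc(Cl)c(Nc4ccccc4)n3)nc2)CC1`: in this assay compound 3 gives 37400 nM.

Compound 1 and compound 2 differ in one place: benzyl in place of phenyl on a nitrogen on an aromatic ring. The step that the two limits leave unreadable from compound 1 to compound 2 cannot be read, because both values sit at the limit of > 100000 nM in this assay, at which 2 of the 3 values shown sit. Among the measured compounds shown here, compound 3 carries a different core from compound 1; that difference is not broken down here, and compound 3 is the only member of the set with a number rather than a limit in this assay.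

Compound 4, `CN1CCN(c2ccc(Nc3ncc(Cl)c(NCc4ccccc4)n3)nc2)CC1`, is not yet measured. It stands to compound 3 as compound 2 stands to compound 1: benzyl in place of phenyl on a nitrogen on an aromatic ring. The place of the change reads the same in both pairs, so this is the same change made on the core of compound 3.

For the measured compounds named here, the one earlier instance of this change gives no readable size, so the expectation for compound 4 rests mainly on the value of compound 3, 37400 nM, with a wide range to allow for an effect in either direction. Compound 4 is estimated at 60000 nM, between 15000 nM and 250000 nM, which means an expected step of a 1.6-fold higher number from compound 3 to compound 4 (0.21 log units; within the scatter). A limit rather than a number is a real possibility for compound 4.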

Compound 4, concentration for 50% growth inhibition: 24800 nM
Compound 4: middle estimate off by 2.4-fold (0.38 log units), on the high side, within the range that was stated.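

In this assay, benzyl in place of phenyl on a nitrogen on an aromatic ring gives a 1.5-fold lower number from compound 3 to compound 4 (0.18 log units; within the scatter), so on the core of compound 3 the change from anilino to benzylamino stays within the usual scatter of the read-out. On the core of compound 1 the same change cannot be read, because compound 1 and compound 2 both stand at a limit of the assay and not at a number: the limit of > 100000 nM in this assay, at which 2 of the 4 values shown sit. This leaves one readable instance of the change in the series, which does not show that the change behaves alike on the two cores, nor that a step of this size would carry over to any other core.

Still open, as far as these compounds go, is whether a group on that nitrogen other than phenyl or benzyl would give a step beyond the scatter, for example a longer chain such as phenethyl, or a benzyl group carrying a carboxylic acid or an amine. Also open is which part of the core of compound 3 accounts for its number, as no pair shown changes the core in one place alone.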